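The source may hold more compounds than are shown below. What is called first, only, known or untested is meant among the compounds shown, and "the series" means these compounds.

Of the compounds shown here, three of one series have been tested in an assay on HL-60 cells for activation of vitamin D3 receptor (Homo sapiens); a lower number here means that less compound is needed, a higher number that more compound is needed for the effect. Compound 1 `CCC(CC)(c1ccc(OCC(=O)C(C)(C)CCCc2ccccc2)c(C)c1)c1ccc(OC[C@@H](O)CO)c(C)c1` carries a phenyl group; in this assay compound 1 reaches only > 30000 nM, which is a limit of the test rather than a number. Compound 2 `CCC(CC)(c1ccc(OCC(=O)C(C)(C)CCCCc2ccccc2)c(C)c1)c1ccc(OC[C@@H](O)CO)c(C)c1` differs from it by benzyl in place of phenyl on a saturated chain carbon, four bonds along the chain from a carbonyl carbon. In this assay compound 2 likewise stops at > 30000 nM, again a limit. Because both sit at the limit of > 30000 nM in this assay, at which 2 of the 3 values shown sit, the step that the two limits leave unreadable from compound 1 to compound 2 cannot be read. Among the compounds with values here, compound 3 `CCC(CC)(c1ccc(OCC(O)C(C)(C)CCCc2ccccc2)c(C)c1)c1ccc(OC[C@@H](O)CO)c(C)c1` keeps the phenyl group but differs from compound 1 in a way that is not broken down here; in this assay compound 3 gives 3600 nM, the only number among the three. Compound 4 `CCC(CC)(c1ccc(OCC(O)C(C)(C)CCCCc2ccccc2)c(C)c1)c1ccc(OC[C@@H](O)CO)c(C)c1` is still to be tested. It differs from compound 3 by benzyl in place of phenyl on a saturated chain carbon, five bonds along the chain from an oxygen on a saturated carbon, the same kind of change as from compound 1 to compound 2, though here five bonds along the chain from an oxygen on a saturated carbon rather than four bonds along the chain from a carbonyl carbon. The earlier step left no readable size, so the step of a 1.2-fold lower number from compound 3 to compound 4 (0.08 log units; within the scatter) is expected to be small. Compound 4 is therefore estimated at 3000 nM, between 1000 nM and 12000 nM.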

Compound 4, half-maximal effective concentration: > 30000 nM
Compound 4 gave a limit, no number (the forecaster's own chance of this, stated with the estimate: 10%); middle value at least 10-fold (1.00 log units) from the limit.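

On the core with an oxygen on a saturated carbon in the chain, benzyl in place of phenyl brings an at least 8.3-fold higher number from compound 3 to compound 4 (0.92 log units; beyond the scatter) in this assay, and this step rests on a limit for compound 4 rather than on a number. On the core with a carbonyl in the chain, the same change cannot be read, because compound 1 and compound 2 both stop at a limit: the limit of > 30000 nM in this assay, at which 3 of the 4 values shown sit. The change is therefore shown to raise the number needed on one core only, and the compounds do not show whether it has the same effect on the other core, since neither end of that pair gives a number.

The compounds shown leave open how a chain ending in an amine or a carboxylic acid instead of the phenyl would behave in this assay. They also leave open whether a chain shorter than that of compound 3 would give a lower number on the same core.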